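Ring contraction on the amide nitrogen of compound 1

This account rests on a few compounds, and the source may have more. Where it says the series, first, only, none or still open, it means among the compounds named here.

Measured compounds:
compound 1 `C=CC(=O)N1CCC[C@@H](N2C(=O)N(Cc3ccccc3)Cc3cnc(Nc4ccc(N5CCN(C)CC5)cc4OC)nc32)C1`: 142 ug/mL
compound 2 `C=CC(=O)N1CC[C@H](N2C(=O)N(C3CCCCC3)Cc3cnc(Nc4ccc(N5CCN(C)CC5)cc4OC)nc32)C1`: 763 ug/mL
compound 3 `C=CC(=O)N1CC[C@H](N2C(=O)N(c3ccccc3)Cc3cnc(Nc4ccc(N5CCN(C)CC5)cc4)nc32)C1`: 976 ug/mL

Of the compounds shown here, three built on a shared core have been measured in a physicochemical assay for solubility, read by HPLC, in phosphate buffer, measured as thermodynamic solubility, with a stated time of 24 h, at pH 6.8; a higher number here means a more soluble compound, a lower number a less soluble compound. Compound 1 gives 142 ug/mL, the lowest of the three numbers. Its nearest neighbour is compound 2, whose value of 763 ug/mL is beyond the scatter above it, and compound 3, with 976 ug/mL, stands furthest away, also beyond the scatter. For the measured compounds named here, compounds 2 and 3 differ from compound 1 in more than one place, so no single step between them and compound 1 can be separated out; their values only show that both sit well above compound 1 in this assay.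

Compound 4 `C=CC(=O)N1CC[C@@H](N2C(=O)N(Cc3ccccc3)Cc3cnc(Nc4ccc(N5CCN(C)CC5)cc4OC)nc32)C1` has not yet been measured. It differs from compound 1 in one place: 1-(vinylcarbonyl)pyrrolidin-3-yl in place of 1-(vinylcarbonyl)piperidin-3-yl on an amide-type nitrogen in a ring. Going by the values given here, no measured pair shows this change on its own, so the size of the step from compound 1 to compound 4 is open. The account expects a modest rise, a 1.8-fold higher number from compound 1 to compound 4 (0.25 log units; within the scatter), and no larger change. Compound 4 is therefore estimated at 250 ug/mL, within a range from 100 ug/mL to 650 ug/mL.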

Compound 4, solubility: 199 ug/mL
Estimate against measurement, compound 4: 1.3-fold (0.10 log units) above; the measured number falls inside the stated range.
By their numbers in this assay, from the lowest: compounds 1 and 4 (each within the scatter of the next); then compounds 2 and 3 (each within the scatter of the next).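

For the compounds shown here, the pair of compound 1 and compound 4 gives the first direct reading of a single change at this position, on an amide-type nitrogen in a ring of the shared core, with the benzyl group and the rest of the structure the same in both. In this assay, putting 1-(vinylcarbonyl)pyrrolidin-3-yl in place of 1-(vinylcarbonyl)piperidin-3-yl, and so a five-membered non-aromatic ring in place of a six-membered one, gives a 1.4-fold higher number from compound 1 to compound 4 (0.15 log units; within the scatter), so this exchange on its own does not separate the two compounds. No measurement is at hand that would bear on this result.

From the compounds shown here alone, it remains open whether the same exchange would give a comparable step with a group other than benzyl on the core, as compound 2 and compound 3 each differ from compound 1 and compound 4 in more than one place and cannot settle this. Also open, going by these compounds, is what an open chain carrying an amine, or one carrying a carboxylic acid, would give in this assay in place of 1-(vinylcarbonyl)pyrrolidin-3-yl on that amide-type nitrogen.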